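A shorter chain on compound 2: what to expect

The source may report more compounds than this note shows. Statements on the series, on what has been measured and on what is new or still open speak of the compounds shown alone.

- Compound 1 `O=C(CCCCCCCc1ccccc1)N[C@H]1CCOC1=O`: > 100000 nM (a limit of the assay)
- Compound 2 `O=C(CCCCCCCCCCc1ccccc1)N[C@H]1CCOC1=O`: 66000 nM
- Compound 3 `O=C(CCCCCCCCCCCc1ccccc1)N[C@H]1CCOC1=O`: > 100000 nM (a limit of the assay)

All three were tested in a functional assay on NCI-H630 cells (Homo sapiens) for cytotoxicity, read by sulforhodamine B assay, with a stated time of 5 days; on this read-out lower numbers stand for stronger inhibition and higher numbers for weaker inhibition. Within the data shown here, compound 2 gives 66000 nM, the only true number here. Compound 1 and compound 3 stand at the limit of > 100000 nM in this assay, at which 2 of the 3 values shown sit.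

Compound 4 `O=C(CCCCCCCCc1ccccc1)N[C@H]1CCOC1=O` is unmeasured. It differs from compound 2 as follows: phenyl in place of phenethyl on a saturated chain carbon, eight bonds along the chain from a carbonyl carbon.

Among the measured compounds shown here, the one measured step on this chain is an at least 1.5-fold higher number from compound 2 to compound 3 (0.18 log units; that floor lies within the scatter). So only a small move towards higher numbers is expected, possibly reaching the limit. The expected change is a 1.5-fold higher number from compound 2 to compound 4 (0.18 log units; within the scatter). For compound 4 the estimated value is 100000 nM, with an expected range of 50000 nM to 180000 nM.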

Compound 4, half-maximal inhibitory concentration: > 100000 nM
Compound 4 gave a limit, no number; the forecaster's own chance of this, stated with the estimate: 60%; the middle value sits exactly at the limit.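

Phenyl in place of phenethyl, on a saturated chain carbon eight bonds along the chain from a carbonyl carbon, gives an at least 1.5-fold higher number from compound 2 to compound 4 (0.18 log units; that floor lies within the scatter). Shortening the chain of compound 2 thus brings no lower number in this assay, just as the longer chain of compound 3 did not, and compound 2 remains the only compound with a true number: the limit of > 100000 nM in this assay, at which 3 of the 4 values shown sit. Compound 1 and compound 4 both stand at a limit, so the step joining them cannot be read.

Going by these compounds, how far above that limit these compounds lie remains open. So does whether an amine or a carboxylic acid in place of the phenyl would give a lower number.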